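Epimeric hydroxyl alcohols: lipophilicity in a carboxylic acid series

This account rests on a few compounds, and the source may have more. Where it says the series, first, only, none or still open, it means among the compounds named here.

Measured compounds:
compound 1, `COc1ccc([C@@H](CCCC(=O)CCc2ccc3c(n2)NCCC3)CC(=O)O)cn1`, 0
compound 2, `COc1ccc([C@@H](CCC[C@@H](O)CCc2ccc3c(n2)NCCC3)CC(=O)O)cn1`, 0

Compound 1 carries a ketone in the chain that links the aryl acid portion to the bicyclic amine; in a physicochemical assay for lipophilicity (a lower number here means a more polar compound, a higher number a more lipophilic compound), compound 1 gives 0. Compound 2 is the alcohol that corresponds to that ketone, drawn with one configuration at the chain carbon; in this assay compound 2 gives 0. Compound 2 stands level with compound 1 at the digits shown, the two values lying within the scatter of each other, so nothing can be said about a difference between the ketone and this alcohol.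

Compound 3, `COc1ccc([C@@H](CCC[C@H](O)CCc2ccc3c(n2)NCCC3)CC(=O)O)cn1`, is the other epimer at that carbon. The difference: the two compounds have the same atoms and bonds and differ only in configuration as drawn: 1 of 2 stereo elements differ; a stereocentre at a saturated chain carbon is drawn R in compound 2 and S in compound 3. Among the measured compounds shown here, no step between measured pairs is available to calibrate such a change. With the same atoms and bonds and only the drawn configuration differing, no shift beyond the scatter is expected from compound 2 to compound 3 in this assay; the expected step is no change at the digits printed from compound 2 to compound 3 (within the scatter). Compound 3 is accordingly estimated at 0, with a range from -0.3 to 0.3.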

Compound 3, partition coefficient: 0.1
For compound 3 the middle estimate is 0.10 log units below the measured one, and the stated range covers the measured number.
By their numbers in this assay, from the lowest: compounds 1, 2 and 3 (each within the scatter of the next).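

Changing the drawn configuration at the saturated chain carbon from R to S gives a number 0.10 log units higher from compound 2 to compound 3 (within the scatter) in this assay. Among the compounds shown here, this is the first step that can be read, and it gives the stereocentre a calibration that compounds 1 and 2 alone could not: at this position, the two epimeric alcohols cannot be told apart by this read-out, so either can stand for the other when only this assay is considered. Their closeness fits what separates the two structures: the fact that compounds 2 and 3 differ only in the configuration as drawn

The compounds shown leave open whether a different group at the same chain carbon, such as an amine or a methyl ether in place of the hydroxyl, would stand apart from the alcohols in this assay. Also open, on these data alone, is whether the same closeness of the epimers would hold with a longer chain linking the aryl acid portion to the bicyclic amine, or with an ester in place of the carboxylic acid.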